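Benzoyl in Place of Acetyl on a Shared Ester

The compounds below may be only part of what the source reports. "The series", "measured", "known", "first", "only" and "open" are said of these compounds alone.

compound 1 `Oc1ccc(Cn2cnc3ccccc32)c2cccnc12`: 4700 nM
compound 2 `CC(=O)Oc1ccc(Cn2ccnc2)c2cccnc12`: "not determined" (no result reported)
compound 3 `CC(=O)Oc1ccc(Cn2cnc(F)c2)c2cccnc12`: 2200 nM

All three share one core and were run in a functional assay on MDA-MB-231 cells (Homo sapiens) for antiproliferative activity, read by luminescence, with a stated time of 72 h; on this read-out higher numbers stand for weaker inhibition and lower numbers for stronger inhibition. Compound 1 gives 4700 nM and compound 3 gives 2200 nM. For compound 2 no number was reported, so it stands nowhere on these values. Compound 4 `O=C(Oc1ccc(Cn2ccnc2)c2cccnc12)c1ccccc1` has not been tested yet. It differs from compound 2 by phenyl in place of methyl on a carbonyl carbon, that is, acetyl to benzoyl. For the measured compounds named here, no measured pair shows this change, and with no value for compound 2 the size and direction of the step in this assay cannot be read from the data. Only the two measured values, both in the low micromolar range, give a bearing. Compound 4 is expected to give about 3000 nM, between 800 nM and 12000 nM.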

Compound 4, half-maximal inhibitory concentration: 12300 nM
For compound 4 the middle estimate is 4.1-fold (0.61 log units) below the measured one, and the stated range ends below it.
By their numbers in this assay, from the lowest: compound 3; then compound 1; then compound 4.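

For the compounds shown here, no step can be read for compound 4, as compound 2, the one compound differing from it in one place, has no value in this assay. Whether acetyl to benzoyl strengthens or weakens inhibition stays open, and nothing shown explains the result for compound 4.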